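A few compounds are considered here, and "the series" means these few. Any claim that something is new, unique, unknown or untested is made for them only; others in the source may bear on it.

In a functional assay on PC-3 cells (Homo sapiens); a higher number here means a weaker inhibitor of growth, a lower number a stronger inhibitor of growth:
- compound 1 `O=S(=O)(/C=C/c1ccccc1)Cc1ccc(Nc2ncnc3ccccc23)cc1`: > 100000 nM (a limit)
- compound 2 `O=S(=O)(/C=C/c1ccc(Cl)c(Cl)c1)Cc1ccc(Nc2ncnc3ccccc23)cc1`: 35000 nM
- compound 3 `CC(C)(C)c1cc(/C=C/S(=O)(=O)Cc2ccc(Nc3ncnc4ccccc34)cc2)cc(C(C)(C)C)c1O`: 7000 nM

Compound 1 sits at the limit of > 100000 nM in this assay, at which 1 of the 3 values shown sits. Of the two actual numbers, compound 2 has the higher, and the gap down to compound 3 lies beyond the scatter.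

Compound 4 `O=S(=O)(/C=C/c1ccc(C(F)(F)F)cc1F)Cc1ccc(Nc2ncnc3ccccc23)cc1` differs from compound 2 as follows: 2-fluoro-4-(trifluoromethyl)phenyl in place of 3,4-dichlorophenyl on a double-bonded chain carbon bound to a double-bonded chain carbon.

The nearest measured step is an at least 2.8-fold lower number from compound 1 to compound 2 (0.45 log units; beyond the scatter). Going by these compounds, it starts from a limit, so its full size is unknown, and it replaces unsubstituted phenyl. Going by the values given here, no measured step exchanges one substituted phenyl for another with only the groups on the ring changed, so no clear shift in either direction is expected. The expected change is a 1.2-fold lower number from compound 2 to compound 4 (0.07 log units; within the scatter). For compound 4 the estimate is 30000 nM, with an expected range of 9000 nM to 100000 nM.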

Compound 4, concentration for 50% growth inhibition: 100000 nM
The estimate for compound 4 lay 3.3-fold (0.52 log units) below the measured number; the range from low to high includes it.
By their numbers in this assay, from the lowest: compound 3; then compound 2; then compound 4.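

In this assay, 2-fluoro-4-(trifluoromethyl)phenyl in place of 3,4-dichlorophenyl on a double-bonded chain carbon bound to a double-bonded chain carbon gives a 2.9-fold higher number from compound 2 to compound 4 (0.46 log units; beyond the scatter). The earlier step only left unsubstituted phenyl, whereas this one shows that the groups on the ring alone move the number. The value of compound 1 is a limit. That leaves only a number no higher from compound 1 to compound 4 (the limit leaves the size open), which cannot be read, because the size stays open: the limit of > 100000 nM in this assay, at which 1 of the 4 values shown sits.

Going by these compounds, the fluoro and trifluoromethyl groups enter together, so their separate shares remain open. Also open, on these data alone, is how a ring carrying an amine or a carboxylic acid would behave here.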